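A few compounds are considered here, and "the series" means these few. Any claim that something is new, unique, unknown or untested is made for them only; others in the source may bear on it.

Compound 1, `Cc1ccc(-c2c(C)nn(-c3nc(-c4ccc(Cl)c(Cl)c4)c(SC(C)C)s3)c2C(=O)O)cc1`, gives 3800 nM in a functional assay on BJAB cells (Homo sapiens) for antiproliferative activity, with a stated time of 4 days; on this read-out lower numbers stand for an effect already at smaller amounts and higher numbers for an effect only at larger amounts of compound. Compound 2, `Cc1ccccc1-c1c(C)nn(-c2nc(-c3ccc(Cl)c(Cl)c3)c(SC(C)C)s2)c1C(=O)O`, gives 5500 nM in this assay. Compound 3, `Cc1nn(-c2nc(-c3ccc(Cl)c(Cl)c3)c(SC(C)C)s2)c(C(=O)O)c1-c1ccc(Cl)cc1`, gives 2500 nM in this assay.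

Among these three numbers compound 1 stands second highest. Its nearest neighbour is compound 2, with a 1.4-fold higher number from compound 1 to compound 2 (0.16 log units; within the scatter); the furthest is compound 3, with a 1.5-fold lower number from compound 1 to compound 3 (0.18 log units; within the scatter). Among the compounds with values here, only the step of a 2.2-fold lower number from compound 2 to compound 3 (0.34 log units; beyond the scatter) reaches beyond the scatter, and even that is modest.

Compound 4, `Cc1nn(-c2nc(-c3ccc(Cl)c(Cl)c3)c(SC(C)C)s2)c(C(=O)O)c1-c1cnccn1`, has not yet been measured. It differs from compound 1 in one place: pyrazin-2-yl in place of 4-methylphenyl on an aromatic carbon. All three measured steps exchange the aromatic group at this same position, and none of them moves the numbers far. None of them, however, swaps a carbon-only ring for a ring with two nitrogen atoms, so the measured steps speak to the place of the change but not to its kind. The expectation is therefore a step of about a 1.2-fold higher number from compound 1 to compound 4 (0.07 log units; within the scatter), with no clear direction. For compound 4 the estimate in this assay is 4500 nM, expected to fall between 1500 nM and 14000 nM.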

Compound 4, half-maximal effective concentration: 14000 nM
Estimate against measurement, compound 4: 3.1-fold (0.49 log units) below; low and high end bracket the measured number.
By their numbers in this assay, from the lowest: compounds 3, 1 and 2 (each within the scatter of the next, the first and the last beyond it); then compound 4.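

Exchanges among the carbon-only rings left the numbers close together, but pyrazin-2-yl at this position raises the number in this assay against all three: (a 3.7-fold higher number from compound 1 to compound 4 (0.57 log units; beyond the scatter)), (a 5.6-fold higher number from compound 3 to compound 4 (0.75 log units; beyond the scatter)) and (a 2.5-fold higher number from compound 2 to compound 4 (0.41 log units; beyond the scatter)). The position therefore responds to the kind of ring it carries and not only to how a carbon-only ring is substituted, although each of these steps is modest. Nothing available explains this shift.

With a single ring containing nitrogen among the compounds shown, it remains open whether the higher number goes with pyrazin-2-yl specifically or with such rings more widely. Pyridin-2-yl and pyrimidin-5-yl would test this, and a phenyl ring carrying an amine or a carboxylic acid is also absent from the compounds shown.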